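The source may hold more compounds than are shown below. What is called first, only, known or untested is meant among the compounds shown, and "the series" means these compounds.

Compound 1 `CCCCCCCCCCc1ccc(-c2noc(CCCNC)n2)cc1`, compound 2 `CCCCCCCCCCc1ccc(-c2noc(-c3cccc(CN)c3)n2)cc1` and compound 3 `CCCCCCCCCCc1ccc(-c2noc([C@@H](N)CCN)n2)cc1` share one core and differ only in the group on the aromatic carbon of the five-membered ring. In an assay on HeLa cells for inhibition of sphingosine-1-phosphate transporter SPNS2 (Mus musculus), read by LC-MS, tested at 2 uM (on this read-out higher numbers stand for more inhibition at the one concentration tested (going by the name of the read-out) and lower numbers for less inhibition), compound 1 gives 45%, compound 2 gives 2% and compound 3 gives 14%. Compound 3 thus stands second of the three: a number 12 percentage points higher from compound 2 to compound 3 (beyond the scatter), while a number 31 percentage points lower from compound 1 to compound 3 (beyond the scatter). The change from compound 1 to compound 2 is the largest measured, a number 43 percentage points lower from compound 1 to compound 2 (beyond the scatter).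

Compound 4 `CCCCCCCCCCc1ccc(-c2noc(CC(O)CN3CCCCC3)n2)cc1` is not yet measured in this assay. It differs from compound 3 by 2-hydroxy-3-(piperidin-1-yl)propyl in place of 1,3-diaminopropyl on an aromatic carbon. For the measured compounds named here, two measured steps touch the 1,3-diaminopropyl group, and both steps that replace one side chain by another are beyond the scatter, so a step of some size is expected here too. Going by the values given here, no measured compound carries the entering group. Given that the closest measured analogue with an open chain, compound 1, gives 45%, an upward step is expected, a number 21 percentage points higher from compound 3 to compound 4 (beyond the scatter). Compound 4 is therefore estimated at 35%, in the range 5% to 70%.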

Compound 4, a percentage reported as inhibition, at one concentration (the size of the read-out at that concentration, not a potency): 2%
Estimate against measurement, compound 4: 33 percentage points above; measured number outside the range, below it.
By their numbers in this assay, from the lowest: compounds 2 and 4 (each within the scatter of the next); then compound 3; then compound 1.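

Even a saturated open chain on this aromatic carbon does not keep the inhibition of compound 1: in this assay, 2-hydroxy-3-(piperidin-1-yl)propyl gives a number 43 percentage points lower from compound 1 to compound 4 (beyond the scatter), and it also gives a number 12 percentage points lower from compound 3 to compound 4 (beyond the scatter). The chain thus does not separate itself from the aryl group of compound 2, with no change at the digits printed from compound 2 to compound 4 (within the scatter), so an open chain and a benzene-type substituent end up level here, and only the 3-(methylamino)propyl group of compound 1 stands apart among the four compounds. No measurement shown offers an explanation for these steps.

Still open, on these data alone, is which part of the entering group goes with the loss, the hydroxyl or the piperidine ring. A 3-(piperidin-1-yl)propyl group without the hydroxyl, or a 2-hydroxy-3-(methylamino)propyl group, would separate the two.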